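This account rests on a few compounds, and the source may have more. Where it says the series, first, only, none or still open, it means among the compounds named here.

Of the compounds shown here, three built on one shared core have been measured in a functional assay on A2780 cells (Homo sapiens) for inhibition, read by MTT assay, with a stated time of 72 h; on this read-out lower numbers stand for stronger inhibition of growth and higher numbers for weaker inhibition of growth. Compound 1 `O=S(=O)(NCCCNCc1ccccc1Cl)c1cc(C(F)(F)F)cc(C(F)(F)F)c1` gives 9300 nM. Compound 2 `O=S(=O)(NCCCNCc1cccc2ccccc12)c1cc(C(F)(F)F)cc(C(F)(F)F)c1` gives 3100 nM, which is the step of a 3.0-fold lower number from compound 1 to compound 2 (0.48 log units; beyond the scatter). Compound 3 `COc1ccc(CNCCCNS(=O)(=O)c2cc(C(F)(F)F)cc(C(F)(F)F)c2)cc1` gives 1700 nM; the step of a 5.5-fold lower number from compound 1 to compound 3 (0.74 log units; beyond the scatter) lies beyond the scatter, whereas the step of a 1.8-fold lower number from compound 2 to compound 3 (0.26 log units; within the scatter) does not. Compound 3 thus carries the lowest of the three numbers, clearly apart from compound 1 but not separable from compound 2.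

Compound 4 `COc1cccc(CNCCCNS(=O)(=O)c2cc(C(F)(F)F)cc(C(F)(F)F)c2)c1` differs from compound 3 by 3-methoxyphenyl in place of 4-methoxyphenyl on a saturated chain carbon bound to an amine nitrogen; the two have the same atoms, joined differently. For the measured compounds named here, none of the measured steps moves a group from one place on a ring to another; each swaps one whole aryl group for another, and the two that run beyond the scatter both leave the 2-chlorophenyl of compound 1. The measured steps therefore give no direct guide, and for compound 4 the expected step of no change at the digits printed from compound 3 to compound 4 (within the scatter) in this assay is none beyond the scatter. Compound 4 is estimated at 1700 nM, with a range from 700 nM to 4500 nM.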

Compound 4, concentration for 50% growth inhibition: 1600 nM
Compound 4: the middle estimate sits 1.1-fold (0.03 log units) above what was measured, and the stated range covers the measured number.
By their numbers in this assay, from the lowest: compounds 4, 3 and 2 (each within the scatter of the next); then compound 1.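

Moving the methoxy group on the ring is a kind of change the earlier steps did not include, and in this assay the step, a 1.1-fold lower number from compound 3 to compound 4 (0.03 log units; within the scatter), shows that 3-methoxyphenyl and 4-methoxyphenyl cannot be told apart at this place. For the compounds shown here, the comparison with the naphthalen-1-yl group, a 1.9-fold lower number from compound 2 to compound 4 (0.29 log units; within the scatter), also stays within the scatter, whereas the one with the 2-chlorophenyl group, a 5.8-fold lower number from compound 1 to compound 4 (0.76 log units; beyond the scatter), runs beyond it, so compound 1 alone stands apart from the other three. Nothing measured here accounts for this pattern.

Open, going by these compounds, is whether 3-chlorophenyl or 4-chlorophenyl would stay with the methoxyphenyl compounds or with compound 1, which would separate the effect of the chlorine from that of its place on the ring. Also open, on these data alone, is what a longer chain would do in the shared core.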